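Chain extension on the dihydroxypyrimidine-type core of compound 1

The compounds below may be only part of what the source reports. "The series", "measured", "known", "first", "only" and "open" are said of these compounds alone.

Compound 1, with structure `CCCCCc1nc(O)cc(O)n1`, is tested in a functional assay on HEK293 cells for agonist activity at G-protein coupled receptor 84 (Homo sapiens), read by calcium flux (on this read-out higher numbers stand for an effect only at larger amounts of compound and lower numbers for an effect already at smaller amounts), and gives 3670 nM. Among the two plain numbers in this assay it stands highest. Its nearest neighbour is compound 3, `CCCCCCCCc1cc(O)nc(O)n1`, which carries a longer chain on a differently arranged core and gives 811 nM, a lower number and beyond the scatter of compound 1. Compound 2, `Oc1cc(C(F)(F)F)nc(SCCCCc2ccccc2)n1`, gives no number in this assay but only a limit, > 100000 nM; this limit is described by the limit of > 100000 nM in this assay, at which 1 of the 3 values shown sits.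

Compound 4, `CCCCCCCCCc1nc(O)cc(O)n1`, keeps the core and chain attachment of compound 1 and differs from it in one place: butyl in place of hydrogen on a saturated chain carbon, five bonds along the chain from an aromatic carbon. The resulting chain counts as many carbons as the chain of compound 3.

Among the compounds with values here, no step between measured compounds that differ in a single place is available, so the direction must be read from the pair of plain numbers. Compound 3 with its longer chain gives 811 nM against compound 1 with 3670 nM, which points toward lower numbers with longer chains, though the core arrangement also differs between them. For compound 4 a lower number than compound 1 is therefore expected, with the step from compound 1 to compound 4 estimated as a 6.1-fold lower number from compound 1 to compound 4 (0.79 log units; beyond the scatter). The estimate for compound 4 is 600 nM, with the likely range 150 nM to 2500 nM.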

Compound 4, half-maximal effective concentration: 48.7 nM
Compound 4: middle estimate off by 12-fold (1.09 log units), on the high side, outside the stated range (below it).
By their numbers in this assay, from the lowest: compound 4; then compound 3; then compound 1. At a limit, above all of these: compound 2.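

In this assay, within the data shown here, butyl in place of hydrogen on a saturated chain carbon, five bonds along the chain from an aromatic carbon, gives a 75-fold lower number from compound 1 to compound 4 (1.88 log units; beyond the scatter) and is the first step read with the core and chain attachment held fixed. The entering butyl brings only carbon, with no ring, no hydrogen-bond donors or acceptors and no net charge, so this large shift goes with chain extension alone, without the change of core arrangement that separates compound 1 from compound 3. The position therefore accepts the extension, and the pentyl chain of compound 1 is not the end point for this read-out.

From the compounds shown here alone, a single step gives no shape for the trend, so it remains open whether a longer chain than that of compound 4 would continue the shift, or whether a carboxylic acid or an amine at the chain end would keep it. Nothing shown here bears on why this chain extension has so large an effect.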